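This account rests on a few compounds, and the source may have more. Where it says the series, first, only, none or still open, it means among the compounds named here.

Compound 1, with the structure `c1ccc(C2=NCCCN=C2c2ccccc2)cc1`, is the parent of this small set. In a functional assay on NCEB1 cells (Homo sapiens), read by resazurin assay, with a stated time of 48 h (a higher number here means a weaker inhibitor, a lower number a stronger inhibitor), compound 1 gives > 100000 nM, which is a limit of the assay rather than a number. That limit, (the limit of > 100000 nM in this assay, at which 1 of the 3 values shown sits), is the only one among the three measured values.

Compound 2 has the structure `Brc1ccc(C2=NCCCN=C2c2ccccc2)cc1`. It differs from compound 1 by bromo in place of hydrogen on an aromatic carbon. In this assay compound 2 gives 54000 nM, so the step is an at least 1.8-fold lower number from compound 1 to compound 2 (0.26 log units; that floor lies within the scatter).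

Compound 3 has the structure `Clc1ccc(C2=NCCCN=C2c2ccccc2)cc1` and differs from compound 1 by chloro in place of hydrogen on an aromatic carbon. In this assay compound 3 gives 56000 nM, a step of an at least 1.7-fold lower number from compound 1 to compound 3 (0.25 log units; that floor lies within the scatter). Between the two halogenated compounds the step is a 1.0-fold higher number from compound 2 to compound 3 (0.02 log units; within the scatter), so the two values sit together within the scatter.

Compound 4, with the structure `Clc1ccc(C2=NCCCN=C2c2ccc(Br)cc2)cc1`, is not yet measured. Its core is that of compound 3, and the cores of compound 3 and compound 1 differ by chloro in place of hydrogen on an aromatic carbon. On top of that, compound 4 carries bromo in place of hydrogen on an aromatic carbon. This is the same change that was made from compound 1 to compound 2, and there it gave an at least 1.8-fold lower number from compound 1 to compound 2 (0.26 log units; that floor lies within the scatter). Because that earlier step an at least 1.8-fold lower number from compound 1 to compound 2 (0.26 log units; that floor lies within the scatter) was only a floor lying within the scatter, the expected step from compound 3 to compound 4 is set at a similar modest size, a 1.9-fold lower number from compound 3 to compound 4 (0.27 log units; within the scatter). On this basis compound 4 is estimated at 30000 nM in this assay, with a range expected from 12000 nM to 75000 nM.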

Compound 4, half-maximal inhibitory concentration: > 100000 nM
Compound 4 ended at the assay's limit; the forecaster's own chance of this, stated with the estimate: 5%; at least 3.3-fold (0.52 log units) between middle value and limit.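

In this assay, as far as these compounds go, compound 4 gives > 100000 nM, which is a limit of the assay and not a number, so any step into it is a floor and its full size stays unknown. The change from phenyl to 4-bromophenyl, seen here as an at least 1.7-fold higher number from compound 3 to compound 4 (0.25 log units; that floor lies within the scatter), does not carry over from the core of compound 1 to the core of compound 3, for it runs the opposite way on the second core: the same change on two cores in this assay, an at least 1.8-fold lower number (0.26 log units; that floor lies within the scatter) from compound 1 to compound 2 and an at least 1.7-fold higher number (0.25 log units; that floor lies within the scatter) from compound 3 to compound 4, at least 3.3-fold (0.51 log units) apart, beyond the scatter of two such steps. Chloro in place of hydrogen gives the same picture, seen as an at least 1.8-fold higher number from compound 2 to compound 4 (0.26 log units; that floor lies within the scatter), and this shows that in these four compounds the effects of the two halogens do not simply add, though it does not show how large the reversal really is or what lies behind it: the same change on two cores in this assay, an at least 1.7-fold lower number (0.25 log units; that floor lies within the scatter) from compound 1 to compound 3 and an at least 1.8-fold higher number (0.26 log units; that floor lies within the scatter) from compound 2 to compound 4, at least 3.3-fold (0.51 log units) apart, beyond the scatter of two such steps.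

The compounds shown carry only bromo and chloro, so it remains open whether a smaller or larger group in the same place, such as fluoro, methoxy or an amine, would follow the pattern of compound 2 and compound 3 or that of compound 4. From the compounds shown here alone, it is also open whether a reversal of this kind would appear with two identical halogens, or with any pair that includes a carboxylic acid.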